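A few compounds are considered here, and "the series" means these few. Any claim that something is new, unique, unknown or untested is made for them only; others in the source may bear on it.

Measured so far:
compound 1 `CNC(=O)CC1CCc2cc(OC)c(OC)cc21` — 33.3%
compound 2 `COc1cc2c(cc1OC)C(CC(=O)NC(C)C)CC2` — 30%

Compound 1 and compound 2 differ only in the amide substituent, and in a functional assay on the whole organism (strain Wistar) for inhibition, with Rattus norvegicus as the target, read by paw edema, with stated times of 60 min and 24 h, at a dose of 100 mg/kg by the oral route (a lower number here means less inhibition, a higher number more inhibition at the dose given (going by the name of the read-out)), the step of a number 3.3 percentage points lower from compound 1 to compound 2 (within the scatter) is within the scatter. Compound 2 thus stands lowest of the two numbers, but not apart from compound 1.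

Compound 3 `COc1cc2c(cc1OC)C(CC(=O)NCc1ccccc1)CC2` carries benzyl in place of isopropyl on an amide-type nitrogen. Among the measured compounds shown here, only the step from compound 1 to compound 2 bears on this change, and it lies within the scatter, so no step beyond the scatter is expected in this assay, in either direction. Compound 3 is therefore estimated at 31% (range 16% to 46%), the expected step being a number 1 percentage points higher from compound 2 to compound 3 (within the scatter).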

Compound 3, a percentage reported as inhibition, in the whole organism at one dose (the size of the read-out at that dose, not a potency): 43.3%
Compound 3: the middle estimate sits 12.3 percentage points below what was measured; the measured number falls inside the stated range.
By their numbers in this assay, from the lowest: compounds 2, 1 and 3 (each within the scatter of the next, the first and the last beyond it).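

Among the compounds shown here, on the amide-type nitrogen, benzyl in place of isopropyl gives the first step beyond the scatter in this assay with a number 13.3 percentage points higher from compound 2 to compound 3 (beyond the scatter) as its size, while a number 10 percentage points higher from compound 1 to compound 3 (within the scatter) keeps the same pair of read-outs from separating when methyl is the starting group. Compound 3 therefore stands apart from compound 2 but not from compound 1. No evidence accounts for this step.

Still open, as far as these compounds go, is whether the step belongs to the benzyl group itself or would also appear with a longer chain such as phenethyl. A carboxylic acid or an amine on the benzyl ring is equally untested by the compounds shown.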